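A few compounds are considered here, and "the series" means these few. Any claim that something is new, unique, unknown or untested is made for them only; others in the source may bear on it.

The compounds measured so far, with their half-maximal inhibitory concentrations for cytotoxicity on prostate cancer cells:

compound 1, `O=C(/C=C/c1ccc(CN2C(=O)/C(=C3\Nc4ccccc4\C3=N/O)c3cc(Br)ccc32)cc1)NO`: 90 nM
compound 2, `O=C(/C=C/c1ccc(CN2C(=O)/C(=C3\Nc4ccccc4\C3=N/O)c3cc(F)ccc32)cc1)NO`: 50 nM
compound 3, `O=C(/C=C/c1ccc(CN2C(=O)/C(=C3\Nc4ccccc4\C3=N/O)c3cc(Cl)ccc32)cc1)NO`: 60 nM

In a functional assay on PC-3 cells (Homo sapiens) for cytotoxicity, read by colorimetric assay (a lower number here means a stronger inhibitor, a higher number a weaker inhibitor), compound 3 gives 60 nM. Its number differs from those of its two neighbours only within the scatter: a 1.5-fold lower number from compound 1 to compound 3 (0.18 log units; within the scatter), and a 1.2-fold higher number from compound 2 to compound 3 (0.08 log units; within the scatter). All three compounds share one core and differ only in the halogen on one aromatic carbon.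

Compound 4, `Cc1ccc2c(c1)/C(=C1/Nc3ccccc3/C1=N\O)C(=O)N2Cc1ccc(/C=C/C(=O)NO)cc1`, changes that same carbon once more: methyl in place of chloro on an aromatic carbon. Going by the values given here, no measured step swaps a halogen for a methyl, so the closest guides are the three halogen exchanges at this position, all of which stayed within the scatter: a 1.8-fold lower number from compound 1 to compound 2 (0.26 log units; within the scatter), a 1.5-fold lower number from compound 1 to compound 3 (0.18 log units; within the scatter), a 1.2-fold higher number from compound 2 to compound 3 (0.08 log units; within the scatter). Those three steps are all small. On that basis, no step beyond the scatter is expected in this assay in either direction.

Compound 4 is therefore expected to give about 60 nM, with a range from 30 nM to 130 nM. For compound 4 this estimate means no change at the digits printed from compound 3 to compound 4 (within the scatter), expected to stay within the scatter.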

Compound 4, half-maximal inhibitory concentration: 60 nM
Compound 4: middle estimate and measured number agree at the digits printed, and the stated range covers the measured number.
By their numbers in this assay, from the lowest: compounds 2, 3, 4 and 1 (each within the scatter of the next).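

In this assay the methyl group on this aromatic carbon stays level with all three halogens: the steps are no change at the digits printed from compound 3 to compound 4 (within the scatter) and a 1.2-fold higher number from compound 2 to compound 4 (0.08 log units; within the scatter) and a 1.5-fold lower number from compound 1 to compound 4 (0.18 log units; within the scatter) and none of them leaves the scatter. The earlier compounds shown here showed only that one halogen could replace another here, whereas this result shows that a small carbon group can also take that place without a readable change in the number. Nothing measured in these compounds explains why the four groups give such similar numbers.

The compounds shown leave open what an amine, a carboxylic acid or a longer chain would do on this same carbon. They also leave open whether the same insensitivity holds at any other position of the shared core.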